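The compounds below may be only part of what the source reports. "The series", "measured", "known", "first", "only" and "open" are said of these compounds alone.

Working notes on the series.

Three compounds have a number or a limit in a functional assay on Bel-7402 cells (Homo sapiens) for cytotoxicity, read by MTT assay (on this read-out lower numbers stand for stronger inhibition and higher numbers for weaker inhibition), so far. Within the data shown here, compound 1 `COc1cc(/C=C/C(=O)c2sc(Nc3cccc(Cl)c3)nc2C)cc(OC)c1OC` is the only one with a measured number: in this assay compound 1 gives 14000 nM, which therefore also marks where the series stands at present. Compound 2 `Cc1ccccc1Nc1nc(C)c(C(=O)/C=C/c2ccccc2)s1` reaches only the limit of the method, giving > 25000 nM in this assay. Compound 3 `Cc1nc(Nc2ccc(Cl)c(Cl)c2)sc1C(=O)/C=C/c1ccc(Cl)cc1` likewise stops at the limit, with > 25000 nM in this assay. Among the measured compounds shown here, since no pair of these differs in a single place, no step between measured compounds can be read; the only generalisation available is the limit of > 25000 nM in this assay, at which 2 of the 3 values shown sit.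

Compound 4 `COc1cc(/C=C/C(=O)c2sc(Nc3ccccc3)nc2C)cc(OC)c1OC` keeps the trimethoxy-substituted side and the shared core of compound 1 and changes only the anilino part: hydrogen in place of chloro on an aromatic carbon. For the measured compounds named here, with no measured step of this kind available, the expectation for the move from compound 1 to compound 4 is modest, a 1.3-fold higher number from compound 1 to compound 4 (0.11 log units; within the scatter), leaning toward weaker rather than stronger inhibition and possibly not beyond the scatter. Compound 4 is accordingly estimated at 18000 nM, within a range from 7000 nM to 40000 nM.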

Compound 4, half-maximal inhibitory concentration: > 25000 nM
Compound 4 ended at the assay's limit (the forecaster's own chance of this, stated with the estimate: 35%); at least 1.3-fold (0.14 log units) between middle value and limit.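

With the trimethoxy-substituted side and the shared core held fixed, the series now has its first readable single-place step in this assay, for hydrogen in place of chloro on an aromatic carbon of the anilino part: an at least 1.7-fold higher number from compound 1 to compound 4 (0.25 log units; that floor lies within the scatter). As far as these compounds go, the direction points toward weaker inhibition without the chloro, but the true size stays unknown, as compound 4 gives only a limit and not a number. The change also leaves compound 1 as the only compound with a measured number, and the remaining compounds sit at one limit: the limit of > 25000 nM in this assay, at which 3 of the 4 values shown sit.

The compounds shown leave open whether a fluoro, methoxy or amine group on that same aromatic carbon would act like chloro or like hydrogen. They also leave open whether the chloro step would hold with a different group in place of the trimethoxy-substituted side.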